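Methyl Steps and Solubility in a Shared Core

This account rests on a few compounds, and the source may have more. Where it says the series, first, only, none or still open, it means among the compounds named here.

Of the compounds shown here, three built on one core have been measured in a physicochemical assay for solubility, in the presence of a further agent that is not named here; a lower number here means a less soluble compound, a higher number a more soluble compound. Compound 1 `Cc1ccc2c(c1)[n+]([O-])c(NCCN1CCCCC1)n[n+]2[O-]` gives 45000000 nM. Compound 2 `CCc1ccc2c(c1)[n+]([O-])c(NCCN1CCCCC1)n[n+]2[O-]` gives 39000000 nM, and compound 3 `CC(C)c1ccc2c(c1)[n+]([O-])c(NCCN(C)C)n[n+]2[O-]` gives 42000000 nM. The change methyl in place of hydrogen on a saturated chain carbon bound to an aromatic carbon produced a 1.2-fold lower number from compound 1 to compound 2 (0.06 log units; within the scatter). Compound 3 carries a different core from compound 1, and the difference between the two cores is not broken down here; its value and that of compound 1 lie within the scatter of each other.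

Compound 4 `CN(C)CCNc1n[n+]([O-])c2ccc(C(C)(C)C)cc2[n+]1[O-]` has not yet been measured in this assay. It differs from compound 3 by methyl in place of hydrogen on a saturated chain carbon bound to an aromatic carbon and two saturated chain carbons. For the measured compounds named here, this is the same kind of change as the one from compound 1 to compound 2, but the place differs: there the carbon was bound to an aromatic carbon only, here it is bound to an aromatic carbon and two saturated chain carbons.

Because a 1.2-fold lower number from compound 1 to compound 2 (0.06 log units; within the scatter) stayed within the scatter, the step to compound 4 is expected to be small as well, a 1.2-fold lower number from compound 3 to compound 4 (0.07 log units; within the scatter). Compound 4 is therefore estimated at 36000000 nM, between 20000000 nM and 60000000 nM.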

Compound 4, solubility: 38000000 nM
Beside the measured number, compound 4's estimate is 1.1-fold (0.02 log units) below it; low and high end bracket the measured number.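

The methyl step on the core of compound 1 gave a 1.2-fold lower number from compound 1 to compound 2 (0.06 log units; within the scatter) in this assay and the step from isopropyl to tert-butyl on the core of compound 3 gave a 1.1-fold lower number from compound 3 to compound 4 (0.04 log units; within the scatter) and thus both stayed within the scatter, even though the carbon that changes is bound to an aromatic carbon only in the first pair and to an aromatic carbon and two saturated chain carbons in the second. This shows that, in these two pairs, the change carried from one core to the other without a step that can be told from the scatter, but it does not show that the change has no effect on any other core or at any other place. Nothing measured here speaks to why the numbers fall as they do.

The compounds shown leave open whether a tert-butyl group on the core of compound 1 would give a similar number. They also leave open whether the numbers would hold with a longer chain, an amine or a carboxylic acid in place of isopropyl or tert-butyl.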